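A Methyl Added to a Second Core: What to Expect

The compounds below may be only part of what the source reports. "The series", "measured", "known", "first", "only" and "open" are said of these compounds alone.

Compound 1, `COC(=O)N(C)CC#CCn1ccnc1`, is the starting point. In a functional assay on the whole organism for agonist activity, with Mus musculus as the target (on this read-out higher numbers stand for an effect only at larger amounts of compound and lower numbers for an effect already at smaller amounts), compound 1 gives 4.5 mg/kg. Compound 2, `COC(=O)N(C)CC#CCn1cncc1C`, carries one extra group; the change is methyl in place of hydrogen on an aromatic carbon. For compound 2 this assay reports only a limit, > 100 mg/kg, and not a number. The step is therefore an at least 22-fold higher number from compound 1 to compound 2 (1.34 log units; beyond the scatter), which rests on (the limit of > 100 mg/kg in this assay, at which 1 of the 3 values shown sits).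

Compound 3, `O=C1NCCN1CC#CCn1ccnc1`, has a different core. In this assay, going by the values given here, compound 3 gives 30 mg/kg, the highest of the two numbers measured so far. How the core of compound 3 differs from that of compound 1 is not broken down here.

Compound 4, `Cc1cncn1CC#CCN1CCNC1=O`, has not yet been measured. It differs from compound 3 by methyl in place of hydrogen on an aromatic carbon. Among the compounds with values here, this is the same change as the one from compound 1 to compound 2, made at the same place on the ring.

Since compound 3 already starts at a higher number than compound 1, the same change is expected to carry it past the limit of this assay. For compound 4 the expected step is a 13-fold higher number from compound 3 to compound 4 (1.12 log units; beyond the scatter), because the same change produced an at least 22-fold higher number from compound 1 to compound 2 (1.34 log units; beyond the scatter). Compound 4 is therefore estimated at 400 mg/kg, with a range from 80 mg/kg to 3000 mg/kg, and most likely this assay will report only a limit for it.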

Compound 4, dose for half-maximal effect: > 100 mg/kg
Compound 4 ended at the assay's limit; the forecaster's own chance of this, stated with the estimate: 75%; the middle value lies beyond the limit too.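

On both cores, methyl in place of hydrogen on an aromatic carbon moves the number the same way: the new step is an at least 3.3-fold higher number from compound 3 to compound 4 (0.52 log units; beyond the scatter), and it sits alongside the earlier at least 22-fold higher number from compound 1 to compound 2 (1.34 log units; beyond the scatter). In this assay, compound 2 and compound 4 both end at a limit and not at a number, so each step gives only the smallest size the change can have: the limit of > 100 mg/kg in this assay, at which 2 of the 4 values shown sit. The direction therefore carries over from the core of compound 1 to the core of compound 3, but nothing can be said about whether the size carries over too: the same change on two cores in this assay, an at least 22-fold higher number (1.34 log units; beyond the scatter) from compound 1 to compound 2 and an at least 3.3-fold higher number (0.52 log units; beyond the scatter) from compound 3 to compound 4; the limit leaves it open whether they differ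

The compounds shown leave open whether a group other than methyl at the same place, such as a fluorine atom, an ethyl group or a longer chain, would also push the number up, and how far a smaller group could go before the effect appears. They also leave open whether the same change would move the number in the same direction on a third core, since two cores are too few to support a general rule for the series.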